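Fluoro to methoxy in the cytotoxicity read-out

A few compounds are considered here, and "the series" means these few. Any claim that something is new, unique, unknown or untested is made for them only; others in the source may bear on it.

As far as these compounds go, compound 1 (`CC(=O)Nc1ccc2oc(-c3ccnc(C(=O)N4CCN(C(c5ccc(F)cc5)c5nnn(C)n5)CC4)c3)nc2c1`) is the starting point in an ADME assay on MDCK cells (Canis lupus familiaris) for cytotoxicity (on this read-out higher numbers stand for lower toxicity in this test and lower numbers for higher toxicity in this test), and gives > 50000 nM as a limit and not a number, so its true position remains open. Compound 2 (`CC(=O)Nc1ccc2oc(-c3ccnc(C(=O)N4CCN([C@@H](c5ccc(F)cc5)c5nnn(C)n5)CC4)c3)nc2c1`) gives > 200000 nM as a limit as well. Among the measured compounds shown here, the only measured step is a step that the two limits leave unreadable from compound 1 to compound 2 and what separates the pair is the fact that one of compounds 1 and 2 is drawn with a defined configuration and the other without, at the place where they differ alone.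

Compound 3 (`COc1ccc(C(c2nnn(C)n2)N2CCN(C(=O)c3cc(-c4nc5cc(NC(C)=O)ccc5o4)ccn3)CC2)cc1`) departs from compound 1 at a different place. The difference is methoxy in place of fluoro on an aromatic carbon and reads as methoxy in place of fluoro on an aromatic carbon, with 4-fluorophenyl becoming 4-methoxyphenyl. For the measured compounds named here, no measured step touches this substituent, and the one step available has no readable size. The expectation therefore rests on compound 1 with > 50000 nM as its limit. No change beyond the scatter is expected in this assay in either direction, and another limit would be no surprise. The expected step is a step that the limit leaves unreadable from compound 1 to compound 3 on that basis. For compound 3 the estimate is 70000 nM with an expected range from 25000 nM to 200000 nM in this series.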

Compound 3, half-maximal cytotoxic concentration: > 50000 nM
Compound 3 was reported as a limit; the forecaster's own chance of this, stated with the estimate: 70%; the middle value lies beyond the limit too.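

Compound 1 and compound 3 are both reported only as limits, so the change from 4-fluorophenyl to 4-methoxyphenyl yields no readable step. The compounds shown leave open where the true values of compound 1, compound 2 and compound 3 lie in this assay, and whether this change shifts the read-out at all.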